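The source may hold more compounds than are shown below. What is called first, only, known or untested is meant among the compounds shown, and "the series" means these compounds.

Compound 2 `COc1cc(C)cc(-c2nn(CC#N)cc2-c2ccnc(-c3ccc(N(C)C)cc3)c2)c1` and compound 1 `Cc1cc(O)cc(-c2nn(CC#N)cc2-c2ccnc(-c3ccc(Oc4ccccc4)cc3)c2)c1` share the same core and differ from each other at two places. In a functional assay on IGROV-1 cells (Homo sapiens) for inhibition, read by sulforhodamine B assay, with a stated time of 48 h (a lower number here means a stronger inhibitor of growth, a higher number a weaker inhibitor of growth), compound 2 gives 30100 nM, the higher of the two numbers, while compound 1 gives 3750 nM. Compound 3 `Cc1cc(O)cc(-c2nn(CC#N)cc2-c2ccnc(-c3ccc(N(C)C)cc3)c2)c1` is compound 2 with hydrogen in place of methyl on an oxygen on an aromatic ring. Going by the values given here, no pair of measured compounds isolates this single change, so the expectation leans on compound 1, whose value of 3750 nM also carries the hydroxy group but beside a different second group. A modest move toward a lower number is expected, a 2.0-fold lower number from compound 2 to compound 3 (0.30 log units; within the scatter). Compound 3 is therefore estimated at 15000 nM, within 4000 nM to 50000 nM.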

Compound 3, concentration for total growth inhibition: 24800 nM
Beside the measured number, compound 3's estimate is 1.7-fold (0.22 log units) below it; the measured number falls inside the stated range.
By their numbers in this assay, from the lowest: compound 1; then compounds 3 and 2 (each within the scatter of the next).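

In this assay, hydroxy in place of methoxy on this aromatic ring gives a 1.2-fold lower number from compound 2 to compound 3 (0.08 log units; within the scatter) and so makes no clear difference with dimethylamino as the second group. The larger difference appears at that second group, where dimethylamino in place of phenoxy gives a 6.6-fold higher number from compound 1 to compound 3 (0.82 log units; beyond the scatter) in this comparison. Nothing available explains either result.

Going by these compounds, whether a larger group on that oxygen, such as ethyl or acetyl, would also leave the number within the scatter remains open. So does whether methoxy and hydroxy would match with phenoxy as the second group.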